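A few compounds are considered here, and "the series" means these few. Any claim that something is new, unique, unknown or untested is made for them only; others in the source may bear on it.

In a functional assay on A549 cells (Homo sapiens) for cytotoxicity, read by sulforhodamine B assay (on this read-out higher numbers stand for weaker inhibition and lower numbers for stronger inhibition), three compounds have been measured so far. Compound 2 `C=C1[C@@H](OC(C)=O)C[C@@H]2[C@](C)(CO[Si](C)(C)C(C)(C)C)[C@H](OC(C)=O)CC[C@@]2(C)[C@@H]1C[C@@H](Nc1ccc(F)cc1)C1=CCOC1=O` gives 4550 nM. For the measured compounds named here, compound 3 `C=C1CC[C@@H]2[C@](C)(CO[Si](C)(C)C(C)(C)C)[C@H](OC(C)=O)CC[C@@]2(C)[C@@H]1C/C=C1/C(=O)OC[C@H]1OC(C)=O` gives 3990 nM, a number within the scatter of the one for compound 2. Compound 1 `C=C1[C@@H](OC(C)=O)C[C@@H]2[C@](C)(COC=O)[C@H](OC(C)=O)CC[C@@]2(C)[C@@H]1C[C@@H](Nc1cccc(F)c1)C1=CCOC1=O` gives 23200 nM, which is beyond the scatter from compound 2 and on the side of weaker inhibition. Compound 2 therefore sits with compound 3, apart from compound 1.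

Compound 4 `C=C1[C@@H](OC(C)=O)C[C@@H]2[C@](C)(CO[Si](C)(C)C(C)(C)C)[C@H](OC(C)=O)CC[C@@]2(C)[C@@H]1C[C@@H](Nc1ccccc1F)C1=CCOC1=O` is the same as compound 2 except for one change, 2-fluorophenyl in place of 4-fluorophenyl on an amine nitrogen. Going by the values given here, no two measured compounds differ in only one place, so the data give no direct measure of such a change. No step beyond the scatter is expected in this assay, and no firm direction can be given. The expected outcome is an estimated 1.1-fold higher number from compound 2 to compound 4 (0.04 log units; within the scatter). In this assay, the estimate for compound 4 is 5000 nM, with an expected range from 2200 nM to 12000 nM.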

Compound 4, half-maximal inhibitory concentration: 3190 nM
For compound 4 the middle estimate is 1.6-fold (0.20 log units) above the measured one; measured number inside the range.
By their numbers in this assay, from the lowest: compounds 4, 3 and 2 (each within the scatter of the next); then compound 1.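

In this assay, for the compounds shown here, 2-fluorophenyl in place of 4-fluorophenyl on an amine nitrogen gives the first reading of a single change in this set (a 1.4-fold lower number from compound 2 to compound 4 (0.15 log units; within the scatter)), and that step lies within the scatter. With the rest of the structure held constant, this exchange of one fluorophenyl group for the other therefore does not separate compound 2 from compound 4 on this read-out. Nothing available here bears on the reason for this result.

The compounds shown leave open how 3-fluorophenyl compares at this amine nitrogen, since compound 1 carries that group but also differs elsewhere from compound 2 and compound 4. They also leave open whether plain phenyl, 4-chlorophenyl or a pyridine ring in this place would give a step beyond the scatter.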